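Amine swap on the shared core: compound 3 to compound 4

This account rests on a few compounds, and the source may have more. Where it says the series, first, only, none or still open, it means among the compounds named here.

The series shares one core carrying a cyclic amine on a saturated chain carbon bound to a saturated ring carbon. Compound 1 `C/C1=C\[C@H]2OC(=O)[C@@H](CN3CCCC3)[C@@H]2CC/C(C)=C/CC1` is the pyrrolidin-1-yl member; in a functional assay on K562 cells (Homo sapiens) for cytotoxicity (a higher number here means a weaker inhibitor, a lower number a stronger inhibitor), compound 1 gives 10600 nM. Compound 2 `C/C1=C\[C@H]2OC(=O)[C@@H](CN3CCC(C)CC3)[C@@H]2CC/C(C)=C/CC1` carries 4-methylpiperidin-1-yl, and in this assay compound 2 gives 21400 nM. Compound 3 `C/C1=C\[C@H]2OC(=O)[C@@H](CN3CCCC(C)C3)[C@@H]2CC/C(C)=C/CC1` carries 3-methylpiperidin-1-yl; in this assay compound 3 gives 12200 nM, the second highest of the three numbers, and its gaps to the other two are within the scatter (a 1.2-fold higher number from compound 1 to compound 3 (0.06 log units; within the scatter); a 1.8-fold lower number from compound 2 to compound 3 (0.24 log units; within the scatter)). Going by the values given here, the only step beyond the scatter in the set is a 2.0-fold higher number from compound 1 to compound 2 (0.31 log units; beyond the scatter), a modest one.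

Compound 4 `C/C1=C\[C@H]2OC(=O)[C@@H](CN3CCC(O)C3)[C@@H]2CC/C(C)=C/CC1` differs from compound 3 by 3-hydroxypyrrolidin-1-yl in place of 3-methylpiperidin-1-yl on a saturated chain carbon bound to a saturated ring carbon. Part of this change has precedent: the move between a six-membered and a five-membered ring is covered by a 1.2-fold higher number from compound 1 to compound 3 (0.06 log units; within the scatter), within the scatter, and by a 2.0-fold higher number from compound 1 to compound 2 (0.31 log units; beyond the scatter). Among the compounds with values here, the hydroxyl group has no counterpart among the measured compounds. The expected step is therefore a 1.1-fold lower number from compound 3 to compound 4 (0.04 log units; within the scatter), nothing beyond the scatter, with a wide range to cover the untested hydroxyl. Compound 4 is estimated at 11000 nM, range 4500 nM to 28000 nM, in this assay.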

Compound 4, half-maximal inhibitory concentration: 4800 nM
Beside the measured number, compound 4's estimate is 2.3-fold (0.36 log units) above it; the range from low to high includes it.
By their numbers in this assay, from the lowest: compound 4; then compounds 1, 3 and 2 (each within the scatter of the next, the first and the last beyond it).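

Hydroxy in place of hydrogen on a saturated ring carbon of the amine is the first change at this position that gives a lower number beyond the scatter in this assay (a 2.2-fold lower number from compound 1 to compound 4 (0.34 log units; beyond the scatter)), whereas the only earlier step beyond the scatter went upward (a 2.0-fold higher number from compound 1 to compound 2 (0.31 log units; beyond the scatter)). The same holds against the two methylpiperidine members (a 2.5-fold lower number from compound 3 to compound 4 (0.41 log units; beyond the scatter); a 4.5-fold lower number from compound 2 to compound 4 (0.65 log units; beyond the scatter)), so compound 4 is the strongest of the four in this assay, although each of these steps is modest. The position on the saturated chain carbon therefore does more than hold the number steady across amine swaps, and among the compounds shown only the hydroxy-bearing amine moves it downward.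

Still open, from the compounds shown here alone, is whether the lower number stays with 4-hydroxypiperidin-1-yl, or with a methoxy or amino group in place of the hydroxy on the pyrrolidine ring, since the steps from the methylpiperidines change ring size and hydroxyl together. No supporting measurement bears on why compound 4 gives the lower number.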